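Chloro for hydrogen on two related cores, growth inhibition

A few compounds are considered here, and "the series" means these few. Any claim that something is new, unique, unknown or untested is made for them only; others in the source may bear on it.

Notes on a small series of benzyl-linked bicyclic compounds tested in a functional assay on SK-MEL-2 cells (Homo sapiens) for cytotoxicity, read by sulforhodamine B assay, with a stated time of 48 h; on this read-out higher numbers stand for weaker inhibition of growth and lower numbers for stronger inhibition of growth. Compound 1 `ClCc1ccccc1Cn1cnc2c(Cl)nc(Cl)nc21` gives 2180 nM in this assay. Compound 2 `ClCc1ccccc1Cn1cnc2c(Cl)ncnc21` gives 2750 nM. Compound 3 `ClCc1ccccc1Cn1cnc2ncnc(Cl)c21` gives 4160 nM; its nearest neighbour in number is compound 2 and its furthest is compound 1, and both gaps are within the scatter, so no order among the three is claimed.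

One step is measured directly: chloro in place of hydrogen on an aromatic carbon a 1.3-fold lower number from compound 2 to compound 1 (0.10 log units; within the scatter). The core of compound 3 and the core of compound 2 are built from the same atoms joined differently; the difference between the two cores is not broken down here.

Compound 4 `ClCc1ccccc1Cn1cnc2nc(Cl)nc(Cl)c21` carries the same change on the core of compound 3: chloro in place of hydrogen on an aromatic carbon. Since the measured step from compound 2 to compound 1 was small and within the scatter, a step of similar size is expected from compound 3 to compound 4 in this assay, namely a 1.3-fold lower number from compound 3 to compound 4 (0.11 log units; within the scatter). On that basis compound 4 is estimated at 3200 nM in this assay, within 1600 nM to 6400 nM.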

Compound 4, concentration for 50% growth inhibition: 2750 nM
The estimate for compound 4 lay 1.2-fold (0.07 log units) above the measured number, and the stated range covers the measured number.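

Chloro in place of hydrogen on an aromatic carbon, here on the core of compound 3, gives a 1.5-fold lower number from compound 3 to compound 4 (0.18 log units; within the scatter) in this assay and, set beside the earlier step, the two agree: the same change on two cores in this assay, a 1.3-fold lower number (0.10 log units; within the scatter) from compound 2 to compound 1 and a 1.5-fold lower number (0.18 log units; within the scatter) from compound 3 to compound 4, 1.2-fold (0.08 log units) apart, within the scatter of two such steps

Across these two pairs the change therefore carries from one core to the other with no difference that can be told apart, and on neither core does its step lie beyond the scatter. This does not show that chloro has an effect of its own on growth inhibition, nor that the two cores would answer alike to a different change, since two small steps can agree without either being distinct from repeat variation.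

Still open, on these data alone, is whether an amine, a methoxy group or a longer chain at the same place would move the number beyond the scatter on either core. Also open, as far as these compounds go, is what a hydroxymethyl group or a carboxylic acid would do in place of the chloromethyl group that all four compounds share.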